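The source may report more compounds than this note shows. Statements on the series, on what has been measured and on what is new or still open speak of the compounds shown alone.

Three members of this series have been measured in an ADME assay on microsomes from liver (Mus musculus) for metabolic stability, read by LC-MS, with NADPH named in the record, with a stated time of 60 min, tested at 1 uM, in the absence of a further agent; a lower number here means that less of the compound is left, a higher number that more of the compound is left. Compound 1 `COc1ccc(-c2c(C)nc3c(N4CC[C@@H](NC(=O)c5ccccc5)C4)cc(C)nn23)cc1OC` gives > 95% in this assay, which is a limit of the assay and not a number. Compound 2 `COc1ccc(-c2c(C)nc3c(N4CC[C@@H](NC(=O)NC(C)C)C4)cc(C)nn23)cc1OC` likewise gives > 95% in this assay, again only a limit. Compound 3 `COc1ccc(-c2c(C)nc3c(N4CC[C@@H](NS(=O)(=O)c5ccccc5)C4)cc(C)nn23)cc1OC` gives > 95% in this assay, also a limit. Compound 3 therefore stands where every measured compound of the series stands, as shown by the limit of > 95% in this assay, at which 3 of the 3 values shown sit. The steps between the measured compounds are accordingly not readable in size: a step that the two limits leave unreadable from compound 1 to compound 2, a step that the two limits leave unreadable from compound 1 to compound 3 and a step that the two limits leave unreadable from compound 2 to compound 3.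

Compound 4 `COc1ccc(-c2c(C)nc3c(N4CC[C@@H](n5cc(-c6ccccc6)nn5)C4)cc(C)nn23)cc1OC` is not yet measured. It differs from compound 3 by 4-phenyl-1H-1,2,3-triazol-1-yl in place of (phenylsulfonyl)amino on a saturated ring carbon. The three measured steps bear on this change only loosely: each exchanged the substituent on the same saturated ring carbon, and each left the readout at the limit, so none gives a size or direction to carry over. The expectation for this assay is therefore a step of no readable size, a number at least 5 percentage points lower from compound 3 to compound 4 (that floor lies within the scatter), with compound 4 most likely remaining at or near the limit. Compound 4 is estimated at 90%, with a range from 65% to 99%.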

Compound 4, percent of the compound remaining: "unstable" (no number reported)
For compound 4 the study gives words and no number; the estimate stays without a comparison.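

In this assay, within the data shown here, compound 4 is reported only in the word "unstable", without a number, so no step to compound 4 can be read from compound 1, compound 2 or compound 3. The compounds shown leave open how much of compound 4 remains and how far it lies from the other three, which stand at a limit: the limit of > 95% in this assay, at which 3 of the 4 values shown sit.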